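Methoxy to hydroxy in a two-compound series

The source may report more compounds than this note shows. Statements on the series, on what has been measured and on what is new or still open speak of the compounds shown alone.

Measured so far in a functional assay on A-431 cells (Homo sapiens) for cytotoxicity, read by MTT assay, with a stated time of 48 h; on this read-out lower numbers stand for stronger inhibition and higher numbers for weaker inhibition:
- compound 1 `COc1ccc(/C=C/C(=O)c2cc3ccccc3oc2=O)cc1`: "not active" (no number reported)
- compound 2 `COc1ccc(C2CC(c3cc4ccccc4oc3=O)=NN2C(C)=O)cc1`: 68.7 ug/mL

Going by the values given here, compound 2 holds the only number, since compound 1 gave no number. Not yet measured is compound 3 `CC(=O)N1N=C(c2cc3ccccc3oc2=O)CC1c1ccc(O)cc1`. It differs from compound 2 in one place: hydrogen in place of methyl on an oxygen on an aromatic ring, or 4-methoxyphenyl to 4-hydroxyphenyl. Among the compounds with values here, no measured pair shows this change, so the data do not size it. The expectation therefore stays close to compound 2 at 68.7 ug/mL, with no step beyond the scatter in this assay and no firm direction. The expected step is a 1.2-fold lower number from compound 2 to compound 3 (0.10 log units; within the scatter). The estimated value for compound 3 is 55 ug/mL, with an expected range of 20 ug/mL to 130 ug/mL.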

Compound 3, half-maximal inhibitory concentration: 73 ug/mL
The estimate for compound 3 lay 1.3-fold (0.12 log units) below the measured number; low and high end bracket the measured number.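

Going by these compounds alone, the first measured pair at this position, methoxy to hydroxy, reads a 1.1-fold higher number from compound 2 to compound 3 (0.03 log units; within the scatter) in this assay, so the 4-methoxyphenyl and 4-hydroxyphenyl forms cannot be told apart on this read-out. Removing the methyl from the oxygen on the aromatic ring therefore leaves the number within the scatter, a size that the opening data could not give. No available evidence bears on why the two compounds read alike.

Open, going by these compounds, is whether a longer chain on that oxygen, such as ethoxy, or an amine in place of the hydroxy would move the number beyond the scatter. Also open, on these data alone, is whether the same change would read alike on the core of compound 1, which gave no number.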